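Adding a second fluoro to compound 2

This account rests on a few compounds, and the source may have more. Where it says the series, first, only, none or still open, it means among the compounds named here.

Compound 1 `O=C(Nc1nc(-c2ccc(Cl)cc2)cs1)c1cc([N+](=O)[O-])ccc1Cl`: 12000 nM
Compound 2 `O=C(Nc1nc(-c2cccc(F)c2)cs1)c1cc([N+](=O)[O-])ccc1Cl`: 11000 nM

In an ADME assay on Raji cells (Homo sapiens) for cytotoxicity, with a stated time of 72 h (a higher number here means that more compound is needed for the effect, a lower number that less compound is needed), compound 2 gives 11000 nM and compound 1 gives 12000 nM. These two numbers lie within the usual scatter of each other, so compound 2 cannot be ranked against compound 1.

The next compound, compound 3 `O=C(Nc1nc(-c2ccc(F)c(F)c2)cs1)c1cc([N+](=O)[O-])ccc1Cl`, has not been measured yet. It differs from compound 2 as follows: fluoro in place of hydrogen on an aromatic carbon. In words, this is fluoro in place of hydrogen on an aromatic carbon, ortho to a fluoro group and para to a large group, which turns 3-fluorophenyl into 3,4-difluorophenyl.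

For the measured compounds named here, only one measured step offers a guide: a 1.1-fold lower number from compound 1 to compound 2 (0.04 log units; within the scatter). That step also exchanges groups on an aromatic carbon, with 3-fluorophenyl in place of 4-chlorophenyl, and it stays within the scatter. A single step is thin evidence, but on this basis no shift beyond the scatter is expected in this assay, in either direction. The estimate is no change at the digits printed from compound 2 to compound 3 (within the scatter). Compound 3 is expected at about 11000 nM, with an estimated range of 5500 nM to 22000 nM.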

Compound 3, half-maximal effective concentration: 13000 nM
Estimate against measurement, compound 3: 1.2-fold (0.07 log units) below, and the stated range covers the measured number.
By their numbers in this assay, from the lowest: compounds 2, 1 and 3 (each within the scatter of the next).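

In this assay, for the compounds shown here, fluoro in place of hydrogen on the aromatic carbon ortho to a fluoro group and para to a large group gives a 1.2-fold higher number from compound 2 to compound 3 (0.07 log units; within the scatter), so this is the first view of a simple addition to the ring rather than an exchange of one substituted phenyl group for another. Comparing the 3,4-difluorophenyl group with the 4-chlorophenyl group gives a 1.1-fold higher number from compound 1 to compound 3 (0.03 log units; within the scatter), so compounds 1, 2 and 3 cannot be ranked against one another, and this position tolerates fluoro in place of hydrogen without a readable shift in this measurement. Nothing available explains why the numbers stay so close.

The compounds shown carry only fluoro or chloro on this phenyl ring, so it remains open whether an amine, a carboxylic acid or a longer chain at the same carbon would move the number beyond the scatter. The rest of the shared core is identical in all three compounds, which leaves open how changes elsewhere in the structure would register in this assay.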